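Halogen swap on the anilino ring: predicting compound 3

This account rests on a few compounds, and the source may have more. Where it says the series, first, only, none or still open, it means among the compounds named here.

Measured compounds:
- compound 1, `Cc1n[nH]c2ccc(-c3nc4cnc(N5CCN(C)CC5)cn4c3Nc3ccccc3F)cc12`: 0%
- compound 2, `Cc1n[nH]c2ccc(-c3nc4cnc(N5CCN(C)CC5)cn4c3Nc3ccc(Br)cc3)cc12`: 11.7%

In a functional assay on CWR22R cells (Homo sapiens) for inhibition, with a stated time of 120 h, tested at 10 uM (on this read-out lower numbers stand for less inhibition and higher numbers for more inhibition at the one concentration tested (going by the name of the read-out)), compound 1 gives 0%. Compound 2 gives 11.7%, the higher of the two numbers; the step of a number 11.7 percentage points higher from compound 1 to compound 2 (beyond the scatter) is modest.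

Compound 3, `Cc1n[nH]c2ccc(-c3nc4cnc(N5CCN(C)CC5)cn4c3Nc3ccc(Cl)cc3Cl)cc12`, carries a new change: 2,4-dichlorophenyl in place of 4-bromophenyl on a nitrogen on an aromatic ring. Among the compounds with values here, only the step from compound 1 to compound 2 bears on it, and it was small, so a small upward step or none beyond the scatter is expected in this assay. Compound 3 is expected to give 14%, in the range 0% to 30%, an estimated step of a number 2.3 percentage points higher from compound 2 to compound 3 (within the scatter).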

Compound 3, a percentage reported as inhibition, at one concentration (the size of the read-out at that concentration, not a potency): 9.53%
Estimate against measurement, compound 3: 4.5 percentage points above; the measured number falls inside the stated range.
By their numbers in this assay, from the lowest: compounds 1, 3 and 2 (each within the scatter of the next, the first and the last beyond it).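

In this assay, 2,4-dichlorophenyl in place of 4-bromophenyl gives a number 2.2 percentage points lower from compound 2 to compound 3 (within the scatter) and, in place of 2-fluorophenyl, gives a number 9.5 percentage points higher from compound 1 to compound 3 (within the scatter) as the second step. Within the data shown here, a ring with two chlorine atoms therefore separates from neither of the single-halogen rings at this position on the nitrogen, so the one step beyond the scatter is still the earlier one. No supporting measurement explains this result.

As far as these compounds go, a phenyl ring carrying an amine or a carboxylic acid remains open. So does whether any replacement for this ring gives much more inhibition.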